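The source may hold more compounds than are shown below. What is called first, only, known or untested is meant among the compounds shown, and "the series" means these compounds.

The account starts from compound 1 `COc1cc(-c2nnc3n2NC(c2ccco2)C(C(=O)C2CC2)S3)cc(OC)c1OC` and leads to compound 4 `COc1cccc(C(=O)C2Sc3nnc(-c4cc(OC)c(OC)c(OC)c4)n3NC2c2ccco2)c1`, which has not yet been measured. In a functional assay on MCF7 cells (Homo sapiens) for cytotoxicity, read by MTT assay, with a stated time of 48 h (on this read-out lower numbers stand for stronger inhibition and higher numbers for weaker inhibition), compound 1 gives only > 100000 nM, a limit of the assay rather than a number (the limit of > 100000 nM in this assay, at which 1 of the 3 values shown sits). Two related compounds do give numbers in this assay: compound 2 `COc1cc(-c2nnc3n2NC(c2cccs2)C(C(=O)c2ccc(F)cc2)S3)cc(OC)c1OC` gives 43700 nM, and compound 3 `COc1ccc(C(=O)C2Sc3nnc(-c4cc(OC)c(OC)c(OC)c4)n3NC2c2cccs2)cc1` gives 49500 nM. Among the compounds with values here, the one measured step between them, a 1.1-fold higher number from compound 2 to compound 3 (0.05 log units; within the scatter), is within the scatter, so methoxy in place of fluoro on an aromatic carbon leaves the read-out where it was. The change from compound 1 to compound 4 is 3-methoxyphenyl in place of cyclopropyl on a carbonyl carbon. Within the data shown here, no measured step covers this change directly; compound 1 is the only compound with a cyclopropyl on the carbonyl carbon, while compounds 2 and 3 both carry an aromatic ring there. Because compound 2 gives 43700 nM and compound 3 gives 49500 nM, a number in their region, rather than a limit, is expected for compound 4. Compound 4 is therefore expected to give about 60000 nM, with a range from 25000 nM to 150000 nM. The step this estimate implies, an at least 1.6-fold lower number from compound 1 to compound 4 (0.22 log units; that floor lies within the scatter), is expected to run toward a lower number, though starting from a limit its size is uncertain.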

Compound 4, half-maximal inhibitory concentration: > 100000 nM
Compound 4 gave a limit, no number; the forecaster's own chance of this, stated with the estimate: 35%; at least 1.6-fold (0.22 log units) between middle value and limit.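

Compound 1 and compound 4 both stop at a limit of this assay rather than at a number, so no step between them can be read: the limit of > 100000 nM in this assay, at which 2 of the 4 values shown sit.

The compounds shown leave open whether 3-methoxyphenyl in place of cyclopropyl on a carbonyl carbon changes the read-out at all, and by how much.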